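The source may report more compounds than this note shows. Statements on the series, on what has been measured and on what is new or still open speak of the compounds shown alone.

Working notes on the series. The shared core is a chlorophenoxy-propanol linked to a piperazine; the variable part sits on the ring nitrogen. In a functional assay on the whole organism (blood) with Rattus norvegicus as the target, at a dose of 100 mg/kg by the oral route (on this read-out higher numbers stand for more inhibition at the one dose given (going by the name of the read-out) and lower numbers for less inhibition), compound 1 `COc1ccc(N2CCN(CC(O)COc3ccc(Cl)cc3)CC2)cc1` gives 4.6%, compound 2 `O=[N+]([O-])c1ccc(N2CCN(CC(O)COc3ccc(Cl)cc3)CC2)cc1` gives 24.8%, and compound 3 `OC(COc1ccc(Cl)cc1)CN1CCN(c2ccc(Cl)c(Cl)c2)CC1` gives 3.52%. Within the data shown here, compound 3 thus has the lowest of the three numbers, though its gap to compound 1 lies within the scatter, as a number 1.1 percentage points lower from compound 1 to compound 3 (within the scatter) shows, while a number 21.3 percentage points lower from compound 2 to compound 3 (beyond the scatter) is the one step beyond the scatter at this position.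

Compound 4 `OC(COc1ccc(Cl)cc1)CN1CCN(C/C=C/c2ccccc2)CC1` is not yet measured. Its change from compound 3 is 3-phenylprop-2-en-1-yl in place of 3,4-dichlorophenyl on an amine nitrogen in a ring. The two measured steps at this ring nitrogen, a number 1.1 percentage points lower from compound 1 to compound 3 (within the scatter) and a number 21.3 percentage points lower from compound 2 to compound 3 (beyond the scatter), both swap one aromatic ring for another; neither covers a group with a double bond outside aromatic rings, so they bear only loosely on the present step. Two of three aryl groups gave low numbers, compound 2 alone standing higher. The working expectation for compound 4 is therefore a number near compound 3, with the step of a number 4.5 percentage points higher from compound 3 to compound 4 (within the scatter) expected to stay within the scatter. Compound 4 is estimated at 8%, within a range of 0% to 25%.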

Compound 4, a percentage reported as inhibition, in the whole organism at one dose (the size of the read-out at that dose, not a potency): 14.6%
Estimate against measurement, compound 4: 6.6 percentage points below; low and high end bracket the measured number.
By their numbers in this assay, from the lowest: compounds 3, 1 and 4 (each within the scatter of the next, the first and the last beyond it); then compound 2.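

In this assay, this ring nitrogen now carries a group with a double bond outside aromatic rings, and 3-phenylprop-2-en-1-yl in place of 3,4-dichlorophenyl gives a number 11.1 percentage points higher from compound 3 to compound 4 (beyond the scatter). Set against 4-nitrophenyl, the same group gives a number 10.2 percentage points lower from compound 2 to compound 4 (beyond the scatter), which leaves the nitro-bearing compound with the highest number shown, while against 4-methoxyphenyl it gives a number 10 percentage points higher from compound 1 to compound 4 (within the scatter), so no order can be drawn for that pair. No measurement at hand accounts for these steps.

The compounds shown leave open whether the double bond or the chain goes with the higher number, a question that a saturated 3-phenylpropyl chain or a benzyl group at this nitrogen would address. As far as these compounds go, it also remains open how a group without an aromatic ring, such as a simple ethyl chain, would read at this position.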